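The source may report more compounds than this note shows. Statements on the series, on what has been measured and on what is new or still open speak of the compounds shown alone.

Measured so far:
compound 1 `Cn1c(N2N=C(c3ccccc3)CC2c2ccccc2)nc(-c2ccccc2)c(C#N)c1=O` — 2490 nM
compound 2 `Cn1c(N2N=C(c3ccccc3)CC2c2ccc(F)cc2)nc(-c2ccccc2)c(C#N)c1=O` — 8150 nM

In a functional assay on HT-29 cells (Homo sapiens) for antiproliferative activity, with a stated time of 72 h (a higher number here means a weaker inhibitor, a lower number a stronger inhibitor), compound 1 gives 2490 nM and stands as the lower of the two numbers; compound 2 gives 8150 nM. Within the data shown here, the one measured step between them, a 3.3-fold higher number from compound 1 to compound 2 (0.51 log units; beyond the scatter), is fluoro in place of hydrogen on an aromatic carbon of the phenyl on the saturated part of the pyrazoline ring.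

Compound 3 `Cn1c(N2N=C(c3ccccc3)CC2c2ccccc2)nc(-c2ccc(Cl)cc2)c(C#N)c1=O` differs from compound 1 by chloro in place of hydrogen on an aromatic carbon: the chlorine enters on the phenyl carried by the shared core, para to a large group, so the change reads phenyl to 4-chlorophenyl. Among the measured compounds shown here, no measured step touches this ring. For the measured compounds named here, the only step that bears on it at all is a 3.3-fold higher number from compound 1 to compound 2 (0.51 log units; beyond the scatter), a halogen in place of hydrogen on a different phenyl, which raised the number beyond the scatter. That is taken as a weak pointer in the same direction, so a small rise, or none beyond the scatter, is expected for compound 3 in this assay. The step expected from compound 1 is a 1.6-fold higher number from compound 1 to compound 3 (0.21 log units; within the scatter). Compound 3 is estimated at 4000 nM, with a range of 1500 nM to 11000 nM.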

Compound 3, half-maximal inhibitory concentration: 19500 nM
Compound 3: middle estimate off by 4.9-fold (0.69 log units), on the low side; measured number outside the range, above it.
By their numbers in this assay, from the lowest: compound 1; then compound 2; then compound 3.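

Among these compounds, changing phenyl to 4-chlorophenyl in this assay gives a 7.8-fold higher number from compound 1 to compound 3 (0.89 log units; beyond the scatter) and is the first measured change at this ring, which shows that this place para to a large group is not indifferent to a chloro in place of hydrogen. With a 3.3-fold higher number from compound 1 to compound 2 (0.51 log units; beyond the scatter) alongside it, both halogen replacements shown raise the number beyond the scatter and leave compound 1, which carries neither halogen, with the lowest number of the three; neither step goes against this pattern, but the two steps differ in both the halogen and the ring, so they cannot separate the effect of one from the other. Nothing on hand accounts for the rise at either ring.

Open, going by these compounds, is whether the rise belongs to chloro alone or to any group entering at this place, a question that a fluoro, a methyl, a methoxy or an amine on the same ring would address. Also open, on these data alone, is whether a chloro on the other phenyl would give a step like that of the fluoro in compound 2.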